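A diacid side chain on a weakly active amide

A few compounds are considered here, and "the series" means these few. Any claim that something is new, unique, unknown or untested is made for them only; others in the source may bear on it.

Compound 2 `CCn1c(C(=O)N[C@H](CO)CCCO)ccc1C(CC)(CC)c1ccc(OCS(=O)(=O)c2ccccc2)c(C)c1` and compound 1 `CCn1c(C(=O)NCC(=O)OC)ccc1C(CC)(CC)c1ccc(OCS(=O)(=O)c2ccccc2)c(C)c1` share one core and differ only in the group on the amide-type nitrogen. In a functional assay on MCF7 cells (Homo sapiens) for antiproliferative activity, read by MTT assay, with a stated time of 24 h (a lower number here means a stronger inhibitor, a higher number a weaker inhibitor), compound 2 gives 31400 nM. Compound 1 gives in this assay only a limit, > 50000 nM. Compound 2 thus stands at the only number shown in this assay, the other value being a limit, as recorded in the limit of > 50000 nM in this assay, at which 1 of the 2 values shown sits. Going by the values given here, the single measured step is an at least 1.5-fold lower number from compound 1 to compound 2 (0.20 log units; that floor lies within the scatter), and its floor lies within the scatter.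

Compound 3 `CCn1c(C(=O)N[C@@H](CCC(=O)O)C(=O)O)ccc1C(CC)(CC)c1ccc(OCS(=O)(=O)c2ccccc2)c(C)c1` has not yet been measured. It differs from compound 2 by a group of 9 heavy atoms (5 carbon, 4 oxygen; no ring) in place of a group of 7 heavy atoms (5 carbon, 2 oxygen; no ring), on an amide-type nitrogen. Among the compounds with values here, only the step from compound 1 to compound 2 bears on this change, since it too exchanged the group on the amide-type nitrogen, and that step showed nothing beyond the scatter. The step of a 1.3-fold higher number from compound 2 to compound 3 (0.11 log units; within the scatter) is therefore expected to stay within the scatter, with a fair chance that the assay again returns only a limit. For compound 3 in this assay the estimate is 40000 nM, with a range from 15000 nM to 100000 nM.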

Compound 3, half-maximal inhibitory concentration: > 50000 nM
Compound 3 ended at the assay's limit (the forecaster's own chance of this, stated with the estimate: 50%); middle value at least 1.2-fold (0.09 log units) from the limit.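

In this assay, going by these compounds alone, the 1,3-dicarboxypropyl group on the amide-type nitrogen leaves compound 3 with a limit and not a number, so a second group at this position now ends the same way as the group of compound 1: the limit of > 50000 nM in this assay, at which 2 of the 3 values shown sit. Set against compound 2, the only compound here with a number, the result reads as an at least 1.5-fold higher number from compound 2 to compound 3 (0.20 log units; that floor lies within the scatter), and only this floor is known, so the full size of the step may or may not exceed the scatter. Compound 1 and compound 3 both carry limits, the step between them cannot be read, and across the three groups seen so far no readable step on this nitrogen has a floor beyond the scatter.

Going by these compounds, whether any group on this amide-type nitrogen can bring the number well down stays open, and an amine, a longer chain ending in a hydroxyl, or a benzyl group would each put that to the test. Also open, on these data alone, are how compound 1 and compound 3 rank against each other and whether changes elsewhere on the shared core would matter more than this position.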